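This account rests on a few compounds, and the source may have more. Where it says the series, first, only, none or still open, it means among the compounds named here.

Compound 2 `CC(C)c1ccc(C(=O)NC(=O)c2ccccc2O)cc1` gives 19 ug/mL in an ADME assay on L6 cells (Rattus norvegicus) for cytotoxicity, read by resazurin assay, with a stated time of 72 h; on this read-out lower numbers stand for stronger inhibition and higher numbers for weaker inhibition. Among the three measured compounds it holds the second-highest number: compound 1 `Cc1ccc(C(=O)NC(=O)c2ccccc2O)cc1` gives 46 ug/mL in this assay, and compound 3 `CCCCOc1ccc(C(=O)NC(=O)c2ccccc2O)cc1` gives 13 ug/mL. The step of a 1.5-fold lower number from compound 2 to compound 3 (0.16 log units; within the scatter) lies within the scatter, while the steps of a 2.4-fold lower number from compound 1 to compound 2 (0.38 log units; beyond the scatter) and a 3.5-fold lower number from compound 1 to compound 3 (0.55 log units; beyond the scatter) both pass beyond it. Compound 4 `CCN(CC)c1ccc(C(=O)NC(=O)c2ccccc2O)cc1` has not been measured in this assay. It differs from compound 2 in one place: diethylamino in place of isopropyl on an aromatic carbon. Among the compounds with values here, the steps that bear on this change are those at the same aromatic carbon. Replacing methyl with a larger group gave modestly lower numbers in a 2.4-fold lower number from compound 1 to compound 2 (0.38 log units; beyond the scatter) and a 3.5-fold lower number from compound 1 to compound 3 (0.55 log units; beyond the scatter), but exchanging one larger group for another, in a 1.5-fold lower number from compound 2 to compound 3 (0.16 log units; within the scatter), stayed within the scatter. With diethylamino, another group larger than isopropyl, at that carbon, the expected step for compound 4 is a 1.3-fold lower number from compound 2 to compound 4 (0.10 log units; within the scatter), within the scatter or at most slightly toward a lower number. Compound 4 is therefore estimated at 15 ug/mL in this assay, with a range from 7 ug/mL to 35 ug/mL.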

Compound 4, half-maximal inhibitory concentration: 8.2 ug/mL
Compound 4: middle estimate off by 1.8-fold (0.26 log units), on the high side; low and high end bracket the measured number.
By their numbers in this assay, from the lowest: compounds 4, 3 and 2 (each within the scatter of the next, the first and the last beyond it); then compound 1.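

In this assay, an exchange between two groups larger than methyl at this aromatic carbon now passes beyond the scatter, with a 2.3-fold lower number from compound 2 to compound 4 (0.36 log units; beyond the scatter), which the earlier exchange of isopropyl for butoxy did not do. Compound 4 still cannot be separated from compound 3, as a 1.6-fold lower number from compound 3 to compound 4 (0.20 log units; within the scatter) lies within the scatter, while a 5.6-fold lower number from compound 1 to compound 4 (0.75 log units; beyond the scatter) is the widest step yet seen at this carbon. Nothing measured here explains the difference between diethylamino and isopropyl at this place.

Going by these compounds, it remains open whether the nitrogen or the ethyl chains matter more, which a plain amine, a dimethylamino group or a pentyl chain at this carbon could help to separate. Also open, on these data alone, is how a carboxylic acid at this carbon would read in this assay.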